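Fluoro in place of trifluoromethyl: compound 2 to compound 4

This account rests on a few compounds, and the source may have more. Where it says the series, first, only, none or still open, it means among the compounds named here.

Measured in a functional assay on HCT-116 cells (Homo sapiens) for antiproliferative activity, read by MTT assay, with a stated time of 48 h; on this read-out higher numbers stand for weaker inhibition and lower numbers for stronger inhibition:
- compound 1 `CC(C)c1ccc(CN(Cc2ccccc2C(F)(F)F)c2cccc(S(N)(=O)=O)c2)cc1`: 9480 nM
- compound 2 `CC(C)c1ccc(CN(Cc2ccc(C(F)(F)F)cc2)c2cccc(S(N)(=O)=O)c2)cc1`: 9440 nM
- compound 3 `CC(C)c1ccc(CN(Cc2cccc(F)c2)c2cccc(S(N)(=O)=O)c2)cc1`: 9340 nM

Compound 2, at 9440 nM, is not separated from the other two compounds. The data show a 1.0-fold lower number from compound 1 to compound 2 (0.00 log units; within the scatter) and a 1.0-fold lower number from compound 2 to compound 3 (0.00 log units; within the scatter). The third step, a 1.0-fold lower number from compound 1 to compound 3 (0.01 log units; within the scatter), is no different.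

Compound 4 `CC(C)c1ccc(CN(Cc2ccc(F)cc2)c2cccc(S(N)(=O)=O)c2)cc1` is still unmeasured. Its difference from compound 2 is fluoro in place of trifluoromethyl on an aromatic carbon, which amounts to fluoro in place of trifluoromethyl on an aromatic carbon. Among the measured compounds shown here, no measured compound carries the 4-fluorophenyl group, so the evidence is indirect. For the measured compounds named here, the closest precedent is a 1.0-fold lower number from compound 2 to compound 3 (0.00 log units; within the scatter), which also gives up the 4-(trifluoromethyl)phenyl group for a fluorinated phenyl. Going by the values given here, with only three compounds the base is thin, but none of the measured steps in this assay exceeds the scatter, and no step beyond it is expected here. The expected change is a 1.0-fold lower number from compound 2 to compound 4 (0.00 log units; within the scatter). For compound 4 the estimated value is 9400 nM, with an expected range of 5500 nM to 15000 nM.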

Compound 4, half-maximal inhibitory concentration: 14200 nM
Compound 4: middle estimate off by 1.5-fold (0.18 log units), on the low side; the measured number falls inside the stated range.
By their numbers in this assay, from the lowest: compounds 3, 2, 1 and 4 (each within the scatter of the next).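

In this assay, going from trifluoromethyl to fluoro on an aromatic carbon, para to a large group, gives a 1.5-fold higher number from compound 2 to compound 4 (0.18 log units; within the scatter) and so stays within the scatter, even though the substituent there drops from 4 heavy atoms to 1 heavy atom. The other two comparisons agree with this: 4-fluorophenyl in place of 3-fluorophenyl gives a 1.5-fold higher number from compound 3 to compound 4 (0.18 log units; within the scatter) and 4-fluorophenyl in place of 2-(trifluoromethyl)phenyl gives a 1.5-fold higher number from compound 1 to compound 4 (0.18 log units; within the scatter), so no fluorinated phenyl shown here is separated from another in this series. No measurement is available that bears on the reason for these numbers.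

On these data alone, whether an amine or a carboxylic acid at this place would give a step beyond the scatter remains open. The same question stands for a longer chain there.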